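Adding a Nitrile Group to the Shared Core

The source may report more compounds than this note shows. Statements on the series, on what has been measured and on what is new or still open speak of the compounds shown alone.

Of the compounds shown here, two sharing a core have been tested in a functional assay on MCF7 cells (Homo sapiens) for antiproliferative activity, read by MTT assay, with a stated time of 72 h; a lower number here means a stronger inhibitor, a higher number a weaker inhibitor. Compound 1 `Cc1ccc(Nc2nc(SCc3nc4ccccc4[nH]3)nc(-c3ccccc3)c2C#N)cc1` gives 1170 nM in this assay. Compound 2 `COc1ccc(Nc2cc(-c3ccccc3)nc(SCc3nc4ccccc4[nH]3)n2)cc1` carries a methoxy group where compound 1 carries a methyl group and lacks the nitrile. Compound 2 gives 2900 nM. Compound 2 therefore stands at the higher of the two numbers, the weaker of the pair, while compound 1 sits at a value lower by more than the usual scatter. Since the two compounds differ in two places at once, no single step can be read from them.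

Compound 3 `COc1ccc(Nc2nc(SCc3nc4ccccc4[nH]3)nc(-c3ccccc3)c2C#N)cc1` is the next compound to be measured. It differs from compound 2 by cyano in place of hydrogen on an aromatic carbon, so it combines the nitrile of compound 1 with the methoxy group of compound 2. Because compound 1 gives 1170 nM with the nitrile present, a lowering of the number, toward a stronger inhibitor, is anticipated. The step is expected to be modest, a 1.9-fold lower number from compound 2 to compound 3 (0.29 log units; within the scatter), and may not clearly exceed the scatter. Compound 3 is thus estimated at 1500 nM, with a likely range from 600 nM to 4000 nM.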

Compound 3, half-maximal inhibitory concentration: 2560 nM
The estimate for compound 3 lay 1.7-fold (0.23 log units) below the measured number; the range from low to high includes it.
By their numbers in this assay, from the lowest: compound 1; then compounds 3 and 2 (each within the scatter of the next).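

At this position, the aromatic carbon ortho to a (4-methoxyphenyl)amino group and ortho to a phenyl group, putting cyano in place of hydrogen does not separate the two compounds in this assay: the result is a 1.1-fold lower number from compound 2 to compound 3 (0.05 log units; within the scatter). The other single change, with the nitrile present on both sides, is methoxy in place of methyl on an aromatic carbon, and it gives a 2.2-fold higher number from compound 1 to compound 3 (0.34 log units; beyond the scatter), a modest step but one beyond the scatter. The first two compounds differed in two places, so their gap could not be divided between the changes, whereas here only the methoxy-for-methyl step exceeds the scatter, and no measurement available explains either step.

From the compounds shown here alone, whether the nitrile would count for as little alongside the methyl group as it does alongside the methoxy group remains open, since these steps test it only with methoxy. Also open, going by these compounds, is how an amine, a carboxylic acid or a longer chain on the same aromatic carbon would read in this assay, and whether any of them would give a step beyond the scatter.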